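This account rests on a few compounds, and the source may have more. Where it says the series, first, only, none or still open, it means among the compounds named here.

Measured compounds:
compound 1 `COc1cccc(OC)c1C(=O)Nc1c[nH]nc1C(=O)Nc1ccncc1`: > 50000 nM in an ADME assay on MRC5 cells (Homo sapiens) for inhibition, with a stated time of 72 h; on this read-out lower numbers stand for an effect already at smaller amounts and higher numbers for an effect only at larger amounts of compound
compound 2 `COc1cccc(OC)c1C(=O)Nc1c[nH]nc1C(=O)NC1CCN(C(=O)OC(C)(C)C)CC1`: > 50000 nM in this assay
compound 3 `CO[C@H]1CC[C@H](NC(=O)c2n[nH]cc2NC(=O)c2ccc(N3CCN(C)CC3)cc2)CC1`: 20000 nM in this assay

The value recorded for compound 1 in this assay is a limit of the assay and not a number. The value for compound 2 is likewise a limit. Going by the values given here, only compound 3 has a number, and with it compound 3 is the sole measured compound that shows any effect within the tested range; the other two sit at the limit of > 50000 nM in this assay, at which 2 of the 3 values shown sit. Among the compounds with values here, no pair among the measured compounds differs in only one place, so no measured step is available to weigh the change toward compound 4 `COc1cccc(OC)c1C(=O)Nc1c[nH]nc1C(=O)NC1CCCCC1`. Compound 4 differs from compound 1 by cyclohexyl in place of pyridin-4-yl on an amide-type nitrogen. Since compound 1 shows no effect up to the limit, the step that the limit leaves unreadable from compound 1 to compound 4 is expected to be none beyond the scatter, and the new compound is expected to remain at or near the limit. For compound 4 the estimate in this assay is 60000 nM, with an expected range from 30000 nM to 150000 nM.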

Compound 4, half-maximal effective concentration: 35000 nM
Beside the measured number, compound 4's estimate is 1.7-fold (0.23 log units) above it; the measured number falls inside the stated range.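

In this assay, going by these compounds alone, compound 4 gives 35000 nM, a number rather than a limit, and so the first readable value for the core of compound 1 with this amide-type nitrogen position changed. Cyclohexyl in place of pyridin-4-yl at this position gives an at least 1.4-fold lower number from compound 1 to compound 4 (0.15 log units; that floor lies within the scatter), so the change is not shown to go beyond the scatter. The value of compound 1 remains a limit and sets only a floor on this step: the limit of > 50000 nM in this assay, at which 2 of the 4 values shown sit.

The compounds shown do not separate the loss of the aromatic ring from the loss of the hydrogen-bond acceptor counted in pyridin-4-yl. Also open, on these data alone, is how the number would respond to an amine or a carboxylic acid on the cyclohexyl ring, or to a longer chain in its place.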